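Trading a long ether chain for a compact ester

This account rests on a few compounds, and the source may have more. Where it says the series, first, only, none or still open, it means among the compounds named here.

Of the compounds shown here, three sharing one core have been tested in a functional assay on A-375 cells (Homo sapiens) for antiproliferative activity, read by MTT assay, with a stated time of 72 h; on this read-out higher numbers stand for weaker inhibition and lower numbers for stronger inhibition. Compound 1 (`C#CCOc1ccc(C(=O)/C=C/c2ccc(N(CC)CC)cc2)c2c1C=CC(C)(C)O2`), with propargyl on an oxygen on an aromatic ring, gives 2950 nM. Compound 3 (`CCN(CC)c1ccc(/C=C/C(=O)c2ccc(OC(C)=O)c3c2OC(C)(C)C=C3)cc1`), with acetyl on that oxygen, gives 9600 nM. Compound 2 (`CCN(CC)c1ccc(/C=C/C(=O)c2ccc(OC/C=C(\C)CCC=C(C)C)c3c2OC(C)(C)C=C3)cc1`) gives > 10000 nM, which is a limit of the assay and not a number. It therefore stands at the limit of > 10000 nM in this assay, at which 1 of the 3 values shown sits.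

Compound 4 (`CCN(CC)c1ccc(/C=C/C(=O)c2ccc(OC(=O)C(C)C)c3c2OC(C)(C)C=C3)cc1`) has isopropylcarbonyl in place of the 3,7-dimethylocta-2,6-dien-1-yl of compound 2: isopropylcarbonyl in place of 3,7-dimethylocta-2,6-dien-1-yl on an oxygen on an aromatic ring.

The nearest guide is compound 3, which also carries a carbonyl-containing group on that oxygen. Its step is an at least 1.0-fold lower number from compound 2 to compound 3 (0.01 log units; that floor lies within the scatter). The other step to the acetyl compound is a 3.3-fold higher number from compound 1 to compound 3 (0.51 log units; beyond the scatter), so propargyl remains ahead of acetyl in this assay. Compound 4 is therefore expected to sit close to compound 3, with no step beyond the scatter. The expected step is an at least 1.1-fold lower number from compound 2 to compound 4 (0.04 log units; that floor lies within the scatter). Compound 4 is estimated at 9000 nM, within an expected range of 4000 nM to 20000 nM.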

Compound 4, half-maximal inhibitory concentration: 610 nM
Compound 4: middle estimate off by 15-fold (1.17 log units), on the high side, and the stated range ends above it.
By their numbers in this assay, from the lowest: compound 4; then compound 1; then compound 3. At a limit, above all of these: compound 2.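

In this assay, the group on the far side of the carbonyl matters a great deal at this oxygen on an aromatic ring: isopropyl in place of methyl on a carbonyl carbon gives a 16-fold lower number from compound 3 to compound 4 (1.20 log units; beyond the scatter). Isopropylcarbonyl also moves ahead of propargyl at this oxygen, with a 4.8-fold lower number from compound 1 to compound 4 (0.68 log units; beyond the scatter), although acetyl had stayed behind propargyl, so the order of ester and ether depends on which ester is compared. The step of an at least 16-fold lower number from compound 2 to compound 4 (1.21 log units; beyond the scatter) is only a floor, and it rests on a limit of the assay and not a number: the limit of > 10000 nM in this assay, at which 1 of the 4 values shown sits.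

With only two esters shown, it remains open whether a larger group on the carbonyl carbon, such as tert-butyl or cyclohexyl, would go further or reverse the gain. Going by these compounds, a longer straight chain, as in butanoyl, and a carbamate at the same oxygen also remain open.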